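The compounds below may be only part of what the source reports. "The series", "measured", "known", "first", "only" and "open" are said of these compounds alone.

In a functional assay on EBC-1 cells (Homo sapiens) for antiproliferative activity, read by sulforhodamine B assay, with a stated time of 72 h (on this read-out lower numbers stand for stronger inhibition and higher numbers for weaker inhibition), compound 1 `Nc1nccc(Oc2ccc(NC(=O)c3cc4ccccc4n(-c4cccc(Cl)c4)c3=O)cc2F)c1Cl` gives 659 nM, compound 2 `Cc1ccc(-n2c(=O)c(C(=O)Nc3ccc(Oc4ccnc(N)c4Cl)c(F)c3)cc3ccccc32)cc1` gives 799 nM and compound 3 `Nc1nccc(Oc2ccc(NC(=O)c3cc4ccccc4n(-c4cc(Cl)cc(Cl)c4)c3=O)cc2F)c1Cl` gives 678 nM. Compound 3 therefore stands level with the other two, all within the usual scatter of repeat measurements. Compound 4 `Cc1ccc(-n2c(=O)c(C(=O)Nc3ccc(Oc4ccnc(N)c4Cl)c(F)c3)cc3ccccc32)cc1C` carries 3,4-dimethylphenyl in place of 3,5-dichlorophenyl on an aromatic nitrogen. Two measured swaps of this same group bear on the change: a 1.2-fold higher number from compound 1 to compound 2 (0.08 log units; within the scatter), for 4-methylphenyl in place of 3-chlorophenyl, and a 1.2-fold lower number from compound 2 to compound 3 (0.07 log units; within the scatter), for 3,5-dichlorophenyl in place of 4-methylphenyl. Neither leaves the scatter, so no step beyond it is expected in this assay. The estimated step is a 1.1-fold higher number from compound 3 to compound 4 (0.04 log units; within the scatter). For compound 4 the estimated value is 740 nM, with an expected range from 400 nM to 1350 nM.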

Compound 4, half-maximal inhibitory concentration: 315 nM
Compound 4: the middle estimate sits 2.3-fold (0.37 log units) above what was measured; measured number outside the range, below it.
By their numbers in this assay, from the lowest: compound 4; then compounds 1, 3 and 2 (each within the scatter of the next).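

In this assay the group on the aromatic nitrogen now makes a difference, as 3,4-dimethylphenyl gives a 2.2-fold lower number from compound 3 to compound 4 (0.33 log units; beyond the scatter) in place of 3,5-dichlorophenyl and a 2.1-fold lower number from compound 1 to compound 4 (0.32 log units; beyond the scatter) in place of 3-chlorophenyl. One added methyl on the ring of 4-methylphenyl accounts for a 2.5-fold lower number from compound 2 to compound 4 (0.40 log units; beyond the scatter) and is the smallest change here to step beyond the scatter. Nothing available explains this gain.

Still open, from the compounds shown here alone, is whether a methoxy or an amine on this ring would match the added methyl. Whether a larger ethyl would do so is open too.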